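Swapping cyanomethyl for fluoro on the oxetane ring

The source may hold more compounds than are shown below. What is called first, only, known or untested is meant among the compounds shown, and "the series" means these compounds.

Of the compounds shown here, three built on one shared core have been tested in a functional assay on cells for antagonist activity at Free fatty acid receptor 1 (Homo sapiens), read by TR-FRET and inositol phosphate accumulation, with a stated time of 2 h; on this read-out higher numbers stand for weaker inhibition and lower numbers for stronger inhibition. Compound 1 `Fc1ccc(OCc2cc(N3CC4(CCO4)C3)nc(-c3ccccn3)n2)c(F)c1F` gives 501 nM, compound 2 `Fc1ccc(OCc2cc(OCC3COC3)nc(-c3ccccn3)n2)c(F)c1F` gives 316 nM, and compound 3 `N#CCC1(COc2cc(COc3ccc(F)c(F)c3F)nc(-c3ccccn3)n2)COC1` gives 398 nM. Compound 3 stands within the usual scatter of both neighbours: a 1.3-fold lower number from compound 1 to compound 3 (0.10 log units; within the scatter), and a 1.6-fold lower number from compound 1 to compound 2 (0.20 log units; within the scatter). The three numbers are thus indistinguishable by this read-out.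

Compound 4 `Fc1ccc(OCc2cc(OCC3(F)COC3)nc(-c3ccccn3)n2)c(F)c1F` differs from compound 3 in one place: fluoro in place of cyanomethyl on a saturated ring carbon. Among the measured compounds shown here, the only measured step that touches the same ring carbon is the one in which the cyanomethyl group itself was introduced, a 1.3-fold higher number from compound 2 to compound 3 (0.10 log units; within the scatter), and it stayed within the scatter. The two larger replacements on the aromatic carbon, a 1.6-fold lower number from compound 1 to compound 2 (0.20 log units; within the scatter) and a 1.3-fold lower number from compound 1 to compound 3 (0.10 log units; within the scatter), also stayed within the scatter. Nothing in these data points to a shift beyond the scatter for putting a small fluoro group where the cyanomethyl sat.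

Compound 4 is therefore expected to give about 350 nM, in a range from 150 nM to 900 nM. The expected step, a 1.1-fold lower number from compound 3 to compound 4 (0.06 log units; within the scatter), lies within the scatter.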

Compound 4, half-maximal inhibitory concentration in the Free fatty acid receptor 1 assay: 63.1 nM
Compound 4: middle estimate off by 5.5-fold (0.74 log units), on the high side, and the stated range ends above it.
By their numbers in the Free fatty acid receptor 1 assay, from the lowest: compound 4; then compounds 2, 3 and 1 (each within the scatter of the next).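

In the Free fatty acid receptor 1 assay this ring carbon responds after all: fluoro in place of hydrogen gives a 5.0-fold lower number from compound 2 to compound 4 (0.70 log units; beyond the scatter), and fluoro in place of cyanomethyl gives a 6.3-fold lower number from compound 3 to compound 4 (0.80 log units; beyond the scatter), although hydrogen and cyanomethyl there could not be told apart (a 1.3-fold higher number from compound 2 to compound 3 (0.10 log units; within the scatter)). The shift therefore goes with the arrival of fluoro, not with the loss of cyanomethyl, and the fluorinated side chain also stands clear of the amine-linked group of compound 1, with a 7.9-fold lower number from compound 1 to compound 4 (0.90 log units; beyond the scatter). In a physicochemical assay for lipophilicity, at pH 7.4 (a lower number here means a more polar compound, a higher number a more lipophilic compound), compound 3 gives 3.3 and compound 4 gives 4, and compound 4 is also the more lipophilic of its pair: the measured distribution coefficient of compound 3, 3.3, and of compound 4, 4, a number 0.70 log units higher (beyond the scatter)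

The compounds shown leave open whether a methyl, a hydroxyl or a chlorine on this ring carbon would match fluoro. Nor can a single pair tell whether numbers in the Free fatty acid receptor 1 assay and the physicochemical assay move together across this series.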